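This account rests on a few compounds, and the source may have more. Where it says the series, first, only, none or still open, it means among the compounds named here.

Working notes on the series, values from an ADME assay on a cell-free system (plasma, Rattus norvegicus) for metabolic stability, read by LC-MS, with a stated time of 4 h, tested at 100 uM (a higher number here means that more of the compound is left, a lower number that less of the compound is left), as measured so far:

- Compound 1 `O=C(NO)c1cc(F)c(Cn2nnc(-c3ccco3)n2)c(F)c1` gives 100%
- Compound 2 `Cn1c(Sc2ccc(C(=O)NO)cc2)nnc1-c1cccs1` gives 86%
- Compound 3 `Cn1c(Sc2c(F)cc(C(=O)NO)cc2F)nnc1-c1cccs1` gives 87%

Compound 3 (at 87%) cannot be told apart from compound 2 (at 86%). The gap between them lies within the scatter. Compound 1 (at 100%) stands higher than compound 3, and that gap lies beyond the scatter.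

The next compound to be read is compound 4 `Cn1c(Sc2c(F)cc(C(=O)NO)cc2F)nnc1-c1cccnn1`, which has pyridazin-3-yl in place of thiophen-2-yl on an aromatic carbon of a five-membered aromatic ring with 3 nitrogen (pyridazin-3-yl in place of thiophen-2-yl on an aromatic carbon). The rest of compound 3 stays as it is. Among the measured compounds shown here, no measured pair differs in one place only, so the data hold no direct step for this change, and the expectation in this assay rests on the high values of the three measured compounds. The expected change, a number 1 percentage points higher from compound 3 to compound 4 (within the scatter), is none beyond the scatter, with no firm direction. For compound 4 the estimated value is 88%, with an expected range from 74% to 100%.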

Compound 4, percent of the compound remaining: 98%
Beside the measured number, compound 4's estimate is 10 percentage points below it, and the stated range covers the measured number.
By their numbers in this assay, from the lowest: compounds 2 and 3 (each within the scatter of the next); then compounds 4 and 1 (each within the scatter of the next).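

In this assay, among the compounds shown here, this is the first readable step at this place on the five-membered aromatic ring with 3 nitrogen: pyridazin-3-yl in place of thiophen-2-yl gives a number 11 percentage points higher from compound 3 to compound 4 (beyond the scatter), with the rest of the molecule unchanged. For the compounds shown here, the group at this place therefore bears on the read-out, which the earlier compounds could not show, since none of them formed a pair differing in one place. The change replaces a five-membered aromatic ring with 1 hetero atom by a six-membered aromatic ring with 2 hetero atoms, and no measurement available here bears on what lies behind the step.

From the compounds shown here alone, a phenyl or a pyridin-2-yl group at this place would help separate the contribution of ring size from that of the ring nitrogen atoms, and this question stays open on the present compounds. Also open, going by these compounds, is whether pyridazin-3-yl gives a step of similar size on the core of compound 2, where the two fluorine atoms of compound 3 are absent.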